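Swapping the Amide Substituent: From Compound 3 to Compound 4

The compounds below may be only part of what the source reports. "The series", "measured", "known", "first", "only" and "open" are said of these compounds alone.

In an assay for binding affinity to 5-hydroxytryptamine receptor 1F (Homo sapiens), read by radioligand binding (a higher number here means a weaker inhibitor, a lower number a stronger inhibitor), three compounds have been measured so far:

Compound 1, `CCCCCC(=O)Nc1ccc2[nH]cc(C3CCN(C)CC3)c2n1`, gives 13 nM.
Compound 2, `CN1CCC(c2c[nH]c3ccc(NC(=O)C4CC4)nc23)CC1`, gives 9.8 nM.
Compound 3, `CN1CCC(c2c[nH]c3ccc(NC(=O)c4ccc([N+](=O)[O-])cc4)nc23)CC1`, gives 7.7 nM.

All three share one core and differ only in the group on the carbonyl carbon of the amide. Compound 3 sits within the scatter of both its neighbours: a 1.7-fold lower number from compound 1 to compound 3 (0.23 log units; within the scatter) and a 1.3-fold lower number from compound 2 to compound 3 (0.10 log units; within the scatter), and likewise a 1.3-fold lower number from compound 1 to compound 2 (0.12 log units; within the scatter). A pentyl chain, a cyclopropyl ring and a 4-nitrophenyl ring on that carbonyl carbon thus gave numbers that cannot be told apart in this assay.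

Compound 4, `CN1CCC(c2c[nH]c3ccc(NC(=O)c4ccncc4)nc23)CC1`, carries the next variation at the same place: pyridin-4-yl in place of 4-nitrophenyl on a carbonyl carbon. Every measured step that bears on this position was within the scatter, so the expectation is that compound 4 will stay close to compound 3, with a 1.2-fold higher number from compound 3 to compound 4 (0.07 log units; within the scatter) meaning no step beyond the scatter. Compound 4 is therefore estimated at 9 nM in this assay, with a range from 4 nM to 20 nM.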

Compound 4, inhibition constant: 8.4 nM
Estimate against measurement, compound 4: 1.1-fold (0.03 log units) above; measured number inside the range.
By their numbers in this assay, from the lowest: compounds 3, 4, 2 and 1 (each within the scatter of the next).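

For the compounds shown here, compound 4 places a ring with a hetero atom on the carbonyl carbon, which none of the earlier compounds has there, and in this assay it cannot be told apart from any of them: a 1.1-fold higher number from compound 3 to compound 4 (0.04 log units; within the scatter), a 1.2-fold lower number from compound 2 to compound 4 (0.07 log units; within the scatter) and a 1.5-fold lower number from compound 1 to compound 4 (0.19 log units; within the scatter). The step from 4-nitrophenyl to pyridin-4-yl also removes three heavy atoms and the double bond outside aromatic rings, and the number still stays within the scatter, so this position has now taken four different groups with no readable difference. Nothing available here speaks to the reason for this.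

An unsubstituted phenyl ring would be needed to separate the loss of the nitro group from the entry of the ring nitrogen. From the compounds shown here alone, whether a carboxylic acid or an amine on that carbonyl carbon would also stay within the scatter remains open.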